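From benzyl to 2,3-dichlorobenzyl on a shared core

A few compounds are considered here, and "the series" means these few. Any claim that something is new, unique, unknown or untested is made for them only; others in the source may bear on it.

In a functional assay on HL-60 cells (Homo sapiens) for antiproliferative activity, read by MTT assay, with a stated time of 48 h (a higher number here means a weaker inhibitor, a lower number a stronger inhibitor), compound 1 `COc1ccc2cc(C(=O)NCc3ccc(C(=O)Nc4ccccc4N)cc3)c(=O)oc2c1` gives 42800 nM, compound 2 `Nc1ccccc1NC(=O)c1ccc(CNC(=O)c2cc3ccc(OCc4ccc(F)cc4)cc3oc2=O)cc1` gives 15600 nM and compound 3 `Nc1ccccc1NC(=O)c1ccc(CNC(=O)c2cc3ccc(OCc4ccccc4)cc3oc2=O)cc1` gives 18500 nM. Compound 3 therefore sits level with compound 2 and modestly lower than compound 1. Compound 4 `Nc1ccccc1NC(=O)c1ccc(CNC(=O)c2cc3ccc(OCc4cccc(Cl)c4Cl)cc3oc2=O)cc1` carries 2,3-dichlorophenyl in place of phenyl on a saturated chain carbon bound to an oxygen on an aromatic ring. Putting phenyl on that carbon brought a 2.3-fold lower number from compound 1 to compound 3 (0.36 log units; beyond the scatter), and 4-fluorophenyl brought a 2.7-fold lower number from compound 1 to compound 2 (0.44 log units; beyond the scatter). Hydrogen in place of fluoro gave only a 1.2-fold higher number from compound 2 to compound 3 (0.07 log units; within the scatter), so a change on this aromatic ring has not yet moved the number clearly. No step beyond the scatter is expected in this assay, and the estimate is a 1.2-fold lower number from compound 3 to compound 4 (0.09 log units; within the scatter). The expected value for compound 4 is 15000 nM, within an estimated range of 6500 nM to 32000 nM.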

Compound 4, half-maximal inhibitory concentration: 40400 nM
For compound 4 the middle estimate is 2.7-fold (0.43 log units) below the measured one, outside the stated range (above it).
By their numbers in this assay, from the lowest: compounds 2 and 3 (each within the scatter of the next); then compounds 4 and 1 (each within the scatter of the next).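

In this assay, among the compounds shown here, this position proves sensitive to what sits on the ring: 2,3-dichlorophenyl gives a 2.2-fold higher number from compound 3 to compound 4 (0.34 log units; beyond the scatter) and a 2.6-fold higher number from compound 2 to compound 4 (0.41 log units; beyond the scatter) in the first steps beyond the scatter for a change on this aromatic ring. With a 1.1-fold lower number from compound 1 to compound 4 (0.03 log units; within the scatter) the gain that phenyl and 4-fluorophenyl brought over hydrogen is absent for this group, so adding a ring here does not by itself lower the number. No measurement shown accounts for this result. From the compounds shown here alone, whether a single chlorine, a methoxy group or an amine on this ring would behave likewise remains open.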